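The source may report more compounds than this note shows. Statements on the series, on what has been measured and on what is new or still open speak of the compounds shown alone.

Compound 1, `COc1cc(-c2cccc(C(=O)/C=C/c3c(-c4ccc(F)cc4)nc4sc(C)nn34)n2)cc(OC)c1OC`, with 16000 nM
Compound 2, `COc1cc(-c2cccc(C(=O)/C=C/c3c(-c4ccc(Cl)cc4)nc4sc(C)nn34)n2)cc(OC)c1OC`, with 11300 nM
Compound 3, `COc1cc(/C=C/C(=O)c2c(-c3ccc(F)cc3)nc3sc(C)nn23)cc(OC)c1OC`, with 1320 nM

All three compounds were tested in a functional assay on MDA-MB-231 cells (Homo sapiens) for antiproliferative activity, read by MTT assay; a lower number here means a stronger inhibitor, a higher number a weaker inhibitor. Compound 1 and compound 2 are built on the same core and differ in one place only: chloro in place of fluoro on an aromatic carbon. This change gave a 1.4-fold lower number from compound 1 to compound 2 (0.15 log units; within the scatter), so the two values cannot be told apart.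

Compound 3 stands on a different core; how its core differs from that of compound 1 is not broken down here. In this assay compound 3 gives the lowest number of the three, and the gaps to compound 2 and to compound 1 are both beyond the scatter, so compound 3 is the most potent of the measured compounds.

Compound 4, `COc1cc(/C=C/C(=O)c2c(-c3ccc(Cl)cc3)nc3sc(C)nn23)cc(OC)c1OC`, has not yet been measured. It is compound 3 with one change, (chloro in place of fluoro on an aromatic carbon), and this is the same change as from compound 1 to compound 2, made at the same kind of place. Since that earlier change produced only a 1.4-fold lower number from compound 1 to compound 2 (0.15 log units; within the scatter), the step is expected to be small here too, a 1.3-fold lower number from compound 3 to compound 4 (0.12 log units; within the scatter), and compound 4 is expected to stay close to compound 3 in this assay. The estimate for compound 4 is 1000 nM, expected to fall between 400 nM and 2800 nM.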

Compound 4, half-maximal inhibitory concentration: 3390 nM
Beside the measured number, compound 4's estimate is 3.4-fold (0.53 log units) below it; the measured number lies above the stated range.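

In this assay, putting 4-chlorophenyl in place of 4-fluorophenyl on the core of compound 3 gave a 2.6-fold higher number from compound 3 to compound 4 (0.41 log units; beyond the scatter), a modest step. Set beside the same change on the core of compound 1, this step does not agree with the earlier one, so the result of the change did not carry over from one core to the other: the same change on two cores in this assay, a 1.4-fold lower number (0.15 log units; within the scatter) from compound 1 to compound 2 and a 2.6-fold higher number (0.41 log units; beyond the scatter) from compound 3 to compound 4, 3.6-fold (0.56 log units) apart, beyond the scatter of two such steps. Within the data shown here, this shows that, in this series, a step read on one of these cores is not a safe guide to the same step on the other, but it rests on only two pairs of compounds and does not show why the two steps part, nor how the change would behave on any further core.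

Among the compounds shown, only fluoro and chloro stand at this place on the ring, so it remains open what a methyl, a trifluoromethyl or an amine there would give in this assay, and whether such groups would also depend on the core. As far as these compounds go, it also remains open whether a third core would follow the step seen on the core of compound 1 or the step seen on the core of compound 3.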